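This account rests on a few compounds, and the source may have more. Where it says the series, first, only, none or still open, it means among the compounds named here.

Measured so far, in a functional assay on HepG2 cells (Homo sapiens) for inhibition, read by MTT assay, with a stated time of 48 h; on this read-out higher numbers stand for weaker inhibition and lower numbers for stronger inhibition:
Compound 1, `Fc1ccc(CSc2nnc(-c3ccncc3)n2-c2ccccc2)cc1`, gives 15600 nM.
Compound 2, `O=[N+]([O-])c1ccc(CSc2nnc(-c3ccncc3)n2-c2ccccc2)cc1`, reaches only the limit > 50000 nM in this assay.
Compound 3, `O=C(CSc1nnc(-c2ccncc2)n1-c1ccccc1)N/N=C/c1ccc([N+](=O)[O-])cc1`, gives 15900 nM.

Compound 3 holds the higher of the two numbers, yet its nearest neighbour is compound 1, and the two values lie within the scatter of each other. The value of compound 2 is a limit and not a number; it is the single case of the limit of > 50000 nM in this assay, at which 1 of the 3 values shown sits.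

Compound 4, `O=C(CSc1nnc(-c2ccncc2)n1-c1ccccc1)N/N=C/C=C/c1ccccc1`, differs from compound 3 in one place: 2-phenylethenyl in place of 4-nitrophenyl on a carbon with a double bond to nitrogen.

For the measured compounds named here, the one measured step that touches the departing group is an at least 3.2-fold higher number from compound 1 to compound 2 (0.50 log units; beyond the scatter), where nitro in place of fluoro on an aromatic carbon raised the number. Going by the values given here, in compound 4 the 4-nitrophenyl leaves altogether, so that step points, if anywhere, toward a lower number, though the new 2-phenylethenyl has no measured precedent here. The expected step is therefore a modest lowering, a 1.8-fold lower number from compound 3 to compound 4 (0.25 log units; within the scatter). Compound 4 is estimated at 9000 nM, with a range from 3000 nM to 30000 nM.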

Compound 4, half-maximal inhibitory concentration: 8280 nM
Beside the measured number, compound 4's estimate is 1.1-fold (0.04 log units) above it, within the range that was stated.
By their numbers in this assay, from the lowest: compounds 4, 1 and 3 (each within the scatter of the next). At a limit, above all of these: compound 2.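

In this assay the step of a 1.9-fold lower number from compound 3 to compound 4 (0.28 log units; within the scatter) shows that this place, on a carbon with a double bond to nitrogen, takes 2-phenylethenyl for 4-nitrophenyl with the two values staying within the scatter of each other. The loss of the nitro group here therefore gives no clear effect, whereas the swap of fluoro for nitro in the other pair gave the step of an at least 3.2-fold higher number from compound 1 to compound 2 (0.50 log units; beyond the scatter) and so lay beyond the scatter. That earlier step rests on compound 2, whose value is a limit and not a number: the limit of > 50000 nM in this assay, at which 1 of the 4 values shown sits.

From the compounds shown here alone, it remains open whether an amine or a carboxylic acid at this place would move the number beyond the scatter. Going by these compounds, it is equally open whether a saturated 2-phenylethyl chain would read as 2-phenylethenyl does.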